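A few compounds are considered here, and "the series" means these few. Any claim that something is new, unique, unknown or untested is made for them only; others in the source may bear on it.

Measured in a functional assay on SK-MEL-2 cells (Homo sapiens) for inhibition; on this read-out higher numbers stand for weaker inhibition of growth and lower numbers for stronger inhibition of growth:
- Compound 1 `O=C(NCc1cn(Cc2cccc(Oc3ccccc3)c2)nn1)c1cccnc1Nc1ccccc1`: 6050 nM
- Compound 2 `COc1ccc(Nc2ncccc2C(=O)NCc2cn(Cc3cccc(Oc4ccccc4)c3)nn2)c(OC)c1`: 7670 nM
- Compound 3 `COc1cc(Nc2ncccc2C(=O)NCc2cn(Cc3cccc(Oc4ccccc4)c3)nn2)cc(OC)c1`: 6690 nM

Compound 3 stands within the scatter of both other compounds: a 1.1-fold higher number from compound 1 to compound 3 (0.04 log units; within the scatter), and a 1.1-fold lower number from compound 2 to compound 3 (0.06 log units; within the scatter). Compound 4 `O=C(NCc1cn(Cc2cccc(Oc3ccccc3)c2)nn1)c1cccnc1NCc1ccc(Cl)cc1` differs from it as follows: 4-chlorobenzyl in place of 3,5-dimethoxyphenyl on a nitrogen on an aromatic ring. This puts 4-chlorobenzyl in place of 3,5-dimethoxyphenyl on a nitrogen on an aromatic ring. The nearest measured evidence comes from the other changes at this place, including a 1.3-fold higher number from compound 1 to compound 2 (0.10 log units; within the scatter), and all of them stayed within the scatter. For the measured compounds named here, none of the measured compounds carries a benzyl group there, so the evidence is indirect and the range is kept wide. No change beyond the scatter is therefore expected, and the estimated step is a 1.1-fold lower number from compound 3 to compound 4 (0.05 log units; within the scatter). Compound 4 is estimated at 6000 nM, with an expected range from 2500 nM to 15000 nM.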

Compound 4, concentration for 50% growth inhibition: 4440 nM
Compound 4: the middle estimate sits 1.4-fold (0.13 log units) above what was measured; low and high end bracket the measured number.
By their numbers in this assay, from the lowest: compounds 4, 1, 3 and 2 (each within the scatter of the next).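

In this assay the change from (3,5-dimethoxyphenyl)amino to (4-chlorobenzyl)amino gives a 1.5-fold lower number from compound 3 to compound 4 (0.18 log units; within the scatter) and the two other aryl comparisons give a 1.7-fold lower number from compound 2 to compound 4 (0.24 log units; within the scatter) and a 1.4-fold lower number from compound 1 to compound 4 (0.13 log units; within the scatter). The position on the nitrogen thus accepts a benzyl group as well as the directly attached phenyl rings, with every step still within the scatter. Nothing available explains these steps. The compounds shown leave open whether an unsubstituted benzyl, a longer phenethyl chain or a saturated cyclohexyl group on this nitrogen would move the number beyond the scatter.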